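The source may report more compounds than this note shows. Statements on the series, on what has been measured and on what is new or still open speak of the compounds shown alone.

Compound 1, `COc1ccc(/C=C\C(=O)O)c(OCc2cn(-c3ccc(CO)cc3)nn2)c1CC=C(C)C`, gives 27100 nM in a functional assay on NCI-H322 cells (Homo sapiens) for cytotoxicity, read by MTT assay, with a stated time of 24 h; on this read-out higher numbers stand for weaker inhibition and lower numbers for stronger inhibition.
Compound 2, `COc1ccc(/C=C\C(=O)O)c(OCc2cn(-c3ccc(NC(=O)c4ccccc4)cc3)nn2)c1CC=C(C)C`, gives 17200 nM in this assay.
Compound 3, `COc1ccc(/C=C\C(=O)O)c(OCc2cn(-c3nc4ccccc4s3)nn2)c1CC=C(C)C`, gives 23000 nM in this assay.

All three compounds share the same core and differ only in the group attached to an aromatic nitrogen of a five-membered aromatic ring with 3 nitrogen. On the numbers shown, compound 3 has the second highest of the three values; its nearest neighbour is compound 1, and even its furthest neighbour, compound 2, lies within the scatter, so no real ordering among the three can be claimed.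

The step to compound 4, `COc1ccc(/C=C\C(=O)O)c(OCc2cn(-c3ccc(C#N)cc3)nn2)c1CC=C(C)C`, is 4-cyanophenyl in place of 1,3-benzothiazol-2-yl on an aromatic nitrogen. Among the compounds with values here, two measured steps bear on it. The step of a 1.2-fold lower number from compound 1 to compound 3 (0.07 log units; within the scatter) swapped the whole group on that ring nitrogen, and the step of a 1.6-fold lower number from compound 1 to compound 2 (0.20 log units; within the scatter) swapped a substituent on an aromatic carbon of that group; both stayed within the scatter. Exchanging one aromatic group for another at this position has so far left the number essentially unchanged, and a further such exchange is expected to behave the same way.

For compound 4 the expected step is a 1.0-fold lower number from compound 3 to compound 4 (0.02 log units; within the scatter), that is, nothing beyond the scatter. Compound 4 is therefore estimated at 22000 nM, with a range from 9000 nM to 55000 nM.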

Compound 4, half-maximal inhibitory concentration: 18600 nM
Compound 4: the middle estimate sits 1.2-fold (0.07 log units) above what was measured; the range from low to high includes it.
By their numbers in this assay, from the lowest: compounds 2, 4, 3 and 1 (each within the scatter of the next).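

In this assay, the step from the two-ring 1,3-benzothiazol-2-yl to the one-ring 4-cyanophenyl on the aromatic nitrogen is a 1.2-fold lower number from compound 3 to compound 4 (0.09 log units; within the scatter), so removing the five-membered aromatic ring with its sulfur and bringing in a triple bond does not move the number beyond the scatter. The nitrile also matches the two other substituents on an aromatic carbon of the phenyl group: the step from benzamido is a 1.1-fold higher number from compound 2 to compound 4 (0.03 log units; within the scatter), and the step from hydroxymethyl is a 1.5-fold lower number from compound 1 to compound 4 (0.16 log units; within the scatter), so all four compounds now sit within the scatter of each other despite clearly different groups at this position. No measured evidence here gives a reason for this flat picture.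

All four compounds carry an aromatic group on the ring nitrogen, so the compounds shown leave open whether a plain alkyl chain or a cyclohexyl group there, or an amine on the phenyl group, would move the number beyond the scatter. They also leave open whether changing the shared core, for example a methyl ester in place of its carboxylic acid, would matter more than any change at this position.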